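Furan-bearing series: fluoro to methoxy on the carbonyl aryl

This account rests on a few compounds, and the source may have more. Where it says the series, first, only, none or still open, it means among the compounds named here.

The three measured compounds share one core and differ only in the aryl group on the carbonyl carbon: compound 1 `COc1cc(C(=O)C2Sc3nnc(-c4cc(OC)c(OC)c(OC)c4)n3NC2c2ccco2)cc(OC)c1OC`, compound 2 `COc1cc(-c2nnc3n2NC(c2ccco2)C(C(=O)c2ccc(Cl)cc2)S3)cc(OC)c1OC` and compound 3 `COc1cc(-c2nnc3n2NC(c2ccco2)C(C(=O)c2ccc(F)cc2)S3)cc(OC)c1OC`. In a functional assay on A549 cells (Homo sapiens) for cytotoxicity, read by MTT assay, with a stated time of 48 h (on this read-out lower numbers stand for stronger inhibition and higher numbers for weaker inhibition), compound 1 gives 48300 nM, compound 2 gives 51400 nM and compound 3 gives 53700 nM. Compound 3 stands level with both others, since a 1.1-fold higher number from compound 1 to compound 3 (0.05 log units; within the scatter) and a 1.0-fold higher number from compound 2 to compound 3 (0.02 log units; within the scatter), as does a 1.1-fold higher number from compound 1 to compound 2 (0.03 log units; within the scatter). Compound 4 `COc1ccc(C(=O)C2Sc3nnc(-c4cc(OC)c(OC)c(OC)c4)n3NC2c2ccco2)cc1` follows from compound 3 by methoxy in place of fluoro on an aromatic carbon. Among the compounds with values here, the steps that bear on this change, the aryl swaps on the carbonyl carbon and the fluoro-for-chloro exchange, all lie within the scatter, so no step beyond the scatter is expected in this assay in either direction. Compound 4 is therefore estimated at 50000 nM with a range of 25000 nM to 100000 nM. The expected step is a 1.1-fold lower number from compound 3 to compound 4 (0.03 log units; within the scatter).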

Compound 4, half-maximal inhibitory concentration: > 100000 nM
Compound 4: a limit, no number (the forecaster's own chance of this, stated with the estimate: 10%); middle value at least 2.0-fold (0.30 log units) away from the limit.
By their numbers in this assay, from the lowest: compounds 1, 2 and 3 (each within the scatter of the next). At a limit, above all of these: compound 4.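

In this assay, compound 4 reads as a limit of the assay, not a number: the limit of > 100000 nM in this assay, at which 1 of the 4 values shown sits. Within the data shown here, this aryl position is therefore not flat: an at least 2.0-fold higher number from compound 1 to compound 4 (0.31 log units; beyond the scatter) is the first step beyond the scatter, even though the 3,4,5-trimethoxyphenyl of compound 1 also carries methoxy groups. Against the halogen compounds only floors can be read, an at least 1.8-fold higher number from compound 3 to compound 4 (0.27 log units; that floor lies within the scatter) and an at least 1.9-fold higher number from compound 2 to compound 4 (0.28 log units; that floor lies within the scatter), and both lie within the scatter.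

Going by these compounds, how an amine or a hydroxyl in place of fluoro would read remains open. So does whether the gap to compound 1 persists with a phenyl in place of the furan.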